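Swapping oxetanyl for diethylcarbamoyl on the ring amine

The compounds below may be only part of what the source reports. "The series", "measured", "known", "first", "only" and "open" are said of these compounds alone.

Measured so far in an in vitro ADME assay on microsomes from liver (Homo sapiens) for pharmacokinetics, read by LC-MS, with a stated time of 10 min, tested at 1 uM; a higher number here means faster removal of the compound, a lower number slower removal:
- compound 1 `COc1cccc(NC(=O)[C@H]2CN(C)C[C@@H]2c2ccc(/C=C/C(=O)Nc3ccccc3N)cc2)c1`: 14 mL/min/kg
- compound 2 `Cc1cc(NC(=O)[C@H]2CN(C)C[C@@H]2c2ccc(/C=C/C(=O)Nc3ccccc3N)cc2)ccc1Cl`: 15 mL/min/kg
- compound 3 `Nc1ccccc1NC(=O)/C=C/c1ccc([C@H]2CN(C3COC3)C[C@@H]2C(=O)Nc2ccc(Cl)cc2)cc1`: 13 mL/min/kg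

The three numbers lie so close together that repeat measurements could not separate them. Compound 3, at 13 mL/min/kg, therefore stands level with the other two, within the scatter of both.

Compound 4 `CCN(CC)C(=O)N1C[C@H](C(=O)Nc2ccc(Cl)cc2)[C@@H](c2ccc(/C=C/C(=O)Nc3ccccc3N)cc2)C1` has not yet been measured. It carries diethylcarbamoyl in place of oxetan-3-yl on an amine nitrogen in a ring, and the count of that difference is diethylcarbamoyl in place of oxetan-3-yl on an amine nitrogen in a ring.

Going by the values given here, only one measured step offers any guidance, a 1.1-fold higher number from compound 1 to compound 2 (0.03 log units; within the scatter). It is small, but it concerns a group on an amide-type nitrogen, not the amine nitrogen in a ring. Among the compounds with values here, no measured pair changes that amine group alone, so the data give no direct size for this step. Compound 3 differs from compound 1 and compound 2 at that nitrogen, yet its value stays within the scatter of theirs, which gives a weak hint that the number may not move much.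

A small upward drift is expected, but nothing beyond the scatter, with an estimated change of a 1.4-fold higher number from compound 3 to compound 4 (0.14 log units; within the scatter). For compound 4 the estimated clearance in this assay is 18 mL/min/kg, with an expected range from 10 mL/min/kg to 35 mL/min/kg.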

Compound 4, clearance: 19 mL/min/kg
Compound 4: middle estimate off by 1.1-fold (0.02 log units), on the low side; low and high end bracket the measured number.
By their numbers in this assay, from the lowest: compounds 3, 1, 2 and 4 (each within the scatter of the next).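

Going by these compounds alone, replacing oxetan-3-yl with diethylcarbamoyl on the amine nitrogen in the ring gives, in this assay, a 1.5-fold higher number from compound 3 to compound 4 (0.16 log units; within the scatter), and compounds 3 and 4 form the only pair here that differs at this nitrogen alone. The change is a sizeable one on paper: a four-membered ring of 4 heavy atoms leaves, and a group with no ring and 7 heavy atoms enters, yet repeat measurements could not be expected to separate the two numbers. For this pair, then, the larger open group at this position leaves clearance level with the oxetan-3-yl compound, and no other kind of measurement here speaks to why.

As far as these compounds go, only these two groups can be compared on this nitrogen with the same (4-chlorophenyl)carbamoyl group in place, so the size of any step for a group such as a short chain ending in a carboxylic acid, or a benzyl group, remains unknown. From the compounds shown here alone, it also stays open whether the same swap would give a similar step with 3-methoxyphenyl on the amide-type nitrogen.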